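The source may hold more compounds than are shown below. What is called first, only, known or untested is meant among the compounds shown, and "the series" means these compounds.

Measured compounds:

Compound 1, `CCc1ccc2nc(C(=O)Nc3c(F)cc(-c4cccc(F)c4)cc3F)c(C)c(O)c2c1`: in a functional assay on Hep 3B2 cells (Homo sapiens) for antiproliferative activity, read by MTT assay, with a stated time of 24 h, tested at 11.11 ug/mL (on this read-out lower numbers stand for a weaker effect and higher numbers for a stronger effect at the one concentration tested), compound 1 gives 46.3%.
Compound 2, `COc1ccc2nc(C(=O)Nc3ccc(-c4ccccc4)cc3)c(C)c(O)c2c1`: compound 2 gives 36.3%.
Compound 3, `CCc1ccc2nc(C(=O)Nc3c(F)cc(-c4cccc(F)c4)cc3F)c(C)c(C(=O)O)c2c1`: compound 3 gives 27.2%.

Compound 3 stands lowest of the three numbers. Its gap to compound 2 lies within the scatter, whereas compound 1 sits beyond the scatter above it; that pair differs in one place only, and the step of a number 19.1 percentage points lower from compound 1 to compound 3 (beyond the scatter) is a modest fall.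

Compound 4, `COc1ccc2nc(C(=O)Nc3c(F)cc(-c4cccc(F)c4)cc3F)c(C)c(C(=O)O)c2c1`, differs from compound 3 in one place: methoxy in place of ethyl on an aromatic carbon. Among the compounds with values here, the only measured step concerns another position and does not bear on this change. Compound 1 and compound 2 differ in this same place but also elsewhere, and their two values sit within the scatter of each other, so they show nothing about the exchange on its own. Nothing measured here points in either direction, and the expected step of a number 2.2 percentage points lower from compound 3 to compound 4 (within the scatter) is none beyond the scatter. Compound 4 is therefore estimated at 25%, with a range from 12% to 40%.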

Compound 4, a percentage reported as inhibition, at one concentration (the size of the read-out at that concentration, not a potency): 2.34%
For compound 4 the middle estimate is 22.7 percentage points above the measured one; measured number outside the range, below it.
By their numbers in this assay, from the lowest: compound 4; then compounds 3, 2 and 1 (each within the scatter of the next, the first and the last beyond it).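

On the core of compound 3, with carboxy in place, this position proves sensitive to the exchange of ethyl for methoxy, although the two groups have the same number of heavy atoms: in this assay the change gives a number 24.9 percentage points lower from compound 3 to compound 4 (beyond the scatter). Within the data shown here, the earlier compounds offered no clean reading of this position, so this single pair is the first direct sign that the group on this aromatic carbon, meta to a fused ring and para to a fused ring, matters for the read-out. Nothing available here gives a reason for the fall.

Going by these compounds, whether the exchange has the same effect when hydroxy replaces carboxy remains open, since this one pair carries carboxy. Also open, on these data alone, is how an amine or a longer chain such as propyl would fare at this position.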